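This account rests on a few compounds, and the source may have more. Where it says the series, first, only, none or still open, it means among the compounds named here.

Measured compounds:
- compound 1 `C=CC(=O)Nc1cccc(-c2nc3ccccc3s2)c1`: > 25000 nM
- compound 2 `O=C(O)/C=C/C(=O)Nc1cccc(-c2nc3ccccc3s2)c1`: > 25000 nM
- compound 3 `O=C(CCl)Nc1cccc(-c2nc3ccccc3s2)c1`: 8500 nM

In an ADME assay on BJ cells (Homo sapiens) for inhibition, with a stated time of 72 h (a lower number here means that less compound is needed, a higher number that more compound is needed for the effect), compound 1 gives only a limit, > 25000 nM. Compound 2 likewise gives a limit, > 25000 nM. Within the data shown here, compound 3 gives 8500 nM, the only number in the set; the other two values sit at the limit of > 25000 nM in this assay, at which 2 of the 3 values shown sit. The step that the two limits leave unreadable from compound 1 to compound 2 cannot be read. The steps of an at least 2.9-fold lower number from compound 1 to compound 3 (0.46 log units; beyond the scatter) and an at least 2.9-fold lower number from compound 2 to compound 3 (0.46 log units; beyond the scatter) both favour chloromethyl on the carbonyl carbon.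

Compound 4 `O=C(Nc1cccc(-c2nc3ccccc3s2)c1)c1ccc(Cl)nc1Cl` differs from compound 3 in one place: 2,6-dichloropyridin-3-yl in place of chloromethyl on a carbonyl carbon. Among the measured compounds shown here, both readable steps bear on this position, and both run toward chloromethyl; the change now removes chloromethyl, so the direction is reversed, while no measured step puts an aromatic ring on that carbonyl carbon. In this assay a higher number is therefore expected for compound 4, with the step of a 2.4-fold higher number from compound 3 to compound 4 (0.37 log units; beyond the scatter) likely carrying it back toward the limit. Compound 4 is estimated at 20000 nM, between 5000 nM and 80000 nM.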

Compound 4, half-maximal effective concentration: > 25000 nM
Compound 4 was reported as a limit; the forecaster's own chance of this, stated with the estimate: 45%; at least 1.2-fold (0.09 log units) between middle value and limit.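

In this assay compound 4 gives > 25000 nM, a limit of the assay. The only aromatic ring shown on this carbonyl carbon, 2,6-dichloropyridin-3-yl, falls in with vinyl and 2-carboxyethenyl rather than with chloromethyl, with an at least 2.9-fold higher number from compound 3 to compound 4 (0.46 log units; beyond the scatter); the steps to compound 4 from compound 1 and from compound 2 cannot be read. Among the four compounds, chloromethyl alone now gives a readable number at this position, and the other three groups cannot be ranked: the limit of > 25000 nM in this assay, at which 3 of the 4 values shown sit.

Going by these compounds, it remains open whether a readable number is particular to chloromethyl or would also appear with bromomethyl, methyl or a longer chloroalkyl chain on this carbonyl carbon. Phenyl or unsubstituted pyridin-3-yl there would test whether other aromatic rings also stay at the limit.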